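Working notes: chloro in place of methyl

The source may hold more compounds than are shown below. What is called first, only, known or untested is meant among the compounds shown, and "the series" means these compounds.

Going by the values given here, in a functional assay on KB cells (Homo sapiens) for antiproliferative activity, read by MTT assay, with a stated time of 72 h (on this read-out higher numbers stand for weaker inhibition and lower numbers for stronger inhibition), compound 1 (`O=C(Nc1cccc(Br)c1)C(Cl)Cl`) gives 8180 nM as the only number so far. Compound 2 (`Cc1ccc(NC(=O)C(Cl)Cl)cc1`) carries the entry "not determined" (no result reported) and so holds no place on this scale. Compound 3 (`O=C(Nc1ccc(Cl)cc1)C(Cl)Cl`) is the next structure to be read. The change chloro in place of methyl on an aromatic carbon puts chloro in place of methyl on an aromatic carbon. Among the compounds with values here, no measured step is available to size this change, and the missing number for compound 2 gives no direction. In this assay a step no larger than the usual scatter is expected, with no direction favoured. The only anchor for the expectation is compound 1 at 8180 nM on the same read-out. For compound 3 the expected value is 10000 nM with an estimated range from 4000 nM to 25000 nM in this series.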

Compound 3, half-maximal inhibitory concentration: 60800 nM
The estimate for compound 3 lay 6.1-fold (0.78 log units) below the measured number, and the stated range ends below it.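

No step can be read for chloro in place of methyl: compound 2 carries no number, so compound 3 at 60800 nM has no partner to compare with. The compounds shown leave open what this change does to antiproliferative activity. No evidence bearing on this result is available.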